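The source may report more compounds than this note shows. Statements on the series, on what has been measured and on what is new or still open speak of the compounds shown alone.

In a functional assay on DU-145 cells (Homo sapiens) for cytotoxicity, read by MTT assay, with a stated time of 72 h (on this read-out higher numbers stand for weaker inhibition and lower numbers for stronger inhibition), compound 1 `CCNc1cc2nc(-c3ccccc3)nn(-c3ccccc3)c-2cc1=O` gives 220 nM, while compound 2 `O=c1cc2n(-c3ccccc3)nc(-c3ccccc3)nc-2cc1N1CCCC1` gives 2460 nM. Compound 2 therefore holds the higher of the two numbers, making it the weaker inhibitor of this pair. Among the measured compounds shown here, the only measured step, an 11-fold higher number from compound 1 to compound 2 (1.05 log units; beyond the scatter), is large and comes with pyrrolidin-1-yl in place of ethylamino on an aromatic carbon. Compound 3 `O=c1cc2n(-c3ccccc3)nc(-c3ccccc3)nc-2cc1N1CCCCC1` changes the same place, with piperidin-1-yl in place of pyrrolidin-1-yl on an aromatic carbon. The measured step replaced an ethylamino group with a ring, whereas here one non-aromatic ring replaces another. It shows that this place can matter, but no ring-for-ring comparison has been measured. No shift beyond the scatter is therefore expected in this assay, and no direction can be favoured. The expected change is a 1.1-fold higher number from compound 2 to compound 3 (0.02 log units; within the scatter). In this assay, the estimated value for compound 3 is 2600 nM, with an expected range from 900 nM to 7000 nM.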

Compound 3, half-maximal inhibitory concentration: 610 nM
The estimate for compound 3 lay 4.3-fold (0.63 log units) above the measured number; measured number outside the range, below it.
By their numbers in this assay, from the lowest: compound 1; then compound 3; then compound 2.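

In this assay ring size alone proves to matter at this aromatic carbon: the change from the five-membered pyrrolidin-1-yl ring to the six-membered piperidin-1-yl ring gives a 4.0-fold lower number from compound 2 to compound 3 (0.61 log units; beyond the scatter) and so a stronger inhibitor. The larger ring still does not match the open ethylamino group, with a 2.8-fold higher number from compound 1 to compound 3 (0.44 log units; beyond the scatter) and compound 1 remaining the strongest inhibitor of the three. No supporting data explain why the six-membered ring does better than the five-membered one.

The compounds shown leave open whether the trend with ring size continues to a seven-membered ring such as azepan-1-yl. They also leave open whether a longer open chain, such as butylamino, or a ring with oxygen in it, such as morpholin-4-yl, would match or surpass ethylamino.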